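A few compounds are considered here, and "the series" means these few. Any claim that something is new, unique, unknown or untested is made for them only; others in the source may bear on it.

Measured so far in an ADME assay on microsomes from liver (Mus musculus, strain CD-1) for metabolic stability, read by LC-MS, tested at 2 uM (on this read-out higher numbers stand for a longer-lived compound and lower numbers for a shorter-lived compound), for the compounds of this series:

compound 1 `CN(C)S(=O)(=O)c1ccccc1Nc1cc(-c2ccc3ccn(C)c3c2)c2nccnc2c1` gives 0.233 h
compound 2 `CN1CCCC(NS(=O)(=O)c2ccccc2Nc2cc(-c3ccc4ccn(C)c4c3)c3nccnc3c2)C1` gives 0.483 h
compound 3 `CN1CCC(NC(=O)c2ccncc2Nc2cc(-c3ccc4ccn(C)c4c3)c3nccnc3c2)CC1` gives > 1 h (a limit)

Compound 3 stands at > 1 h and this is a limit of this assay rather than a number. Compound 4 `CC(=O)N1CCOC(CNC(=O)c2ccncc2Nc2cc(-c3ccc4ccn(C)c4c3)c3nccnc3c2)C1` keeps the shared core but carries (4-acetylmorpholin-2-yl)methyl in place of 1-methylpiperidin-4-yl on an amide-type nitrogen. Among the measured compounds shown here, no measured step makes this exact change. The nearest guide is a 2.1-fold higher number from compound 1 to compound 2 (0.32 log units; beyond the scatter) on a sulfonyl sulfur rather than an amide-type nitrogen. That step lies beyond the scatter but is modest in size, so in this assay only a small change is expected here, none beyond the scatter. The estimate therefore means an at least 1.2-fold lower number from compound 3 to compound 4 (0.09 log units; that floor lies within the scatter) as the expected step. For compound 4 the estimated half-life is 0.8 h (expected range 0.35 h to 1.6 h).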

Compound 4, half-life: 0.217 h
Compound 4: the middle estimate sits 3.7-fold (0.57 log units) above what was measured; measured number below the stated range.
By their numbers in this assay, from the lowest: compounds 4 and 1 (each within the scatter of the next); then compound 2. At a limit, above all of these: compound 3.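

In this assay, the group on the amide-type nitrogen proves to matter: (4-acetylmorpholin-2-yl)methyl in place of 1-methylpiperidin-4-yl gives an at least 4.6-fold lower number from compound 3 to compound 4 (0.66 log units; beyond the scatter). Among the compounds shown here, the only earlier step, a 2.1-fold higher number from compound 1 to compound 2 (0.32 log units; beyond the scatter), sat on a sulfonyl sulfur and went the other way, so it does not carry over to this nitrogen. The new step gives only a minimum size because compound 3 stands at a limit rather than a number: the limit of > 1 h in this assay, at which 1 of the 4 values shown sits.

The change alters the ring, the group on the ring nitrogen and the link to the amide-type nitrogen all at once, and the compounds shown do not separate these parts. On these data alone, it remains open whether 1-acetylpiperidin-4-yl on this same nitrogen, with an acetyl in place of the methyl on the ring of compound 3, would behave more like compound 3 or compound 4.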